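Fluorine position and cytotoxicity in a shared core

The compounds below may be only part of what the source reports. "The series", "measured", "known", "first", "only" and "open" are said of these compounds alone.

Compound 1 `O=C(Nc1ccc(F)c(-c2nc3ncc(-c4cccc(F)c4)cc3[nH]2)c1)N1CCCC1`, compound 2 `O=C(Nc1ccc(F)c(-c2nc3ncc(-c4ccccc4F)cc3[nH]2)c1)N1CCCC1` and compound 3 `O=C(Nc1ccc(F)c(-c2nc3ncc(-c4cc(F)ccc4F)cc3[nH]2)c1)N1CCCC1` share one core and differ only in which fluorophenyl group sits on it. In an ADME assay on HepG2 cells (Homo sapiens) for cytotoxicity, read by resazurin assay, with a stated time of 48 h (on this read-out higher numbers stand for an effect only at larger amounts of compound and lower numbers for an effect already at smaller amounts), compound 1 gives 28200 nM. Compound 2 reaches only a limit of the measurement, > 50000 nM. Compound 3 likewise reaches only a limit, > 50000 nM. Compound 2 thus stands at the limit of > 50000 nM in this assay, at which 2 of the 3 values shown sit.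

Compound 4 `O=C(Nc1ccc(F)c(-c2nc3ncc(-c4ccc(F)cc4)cc3[nH]2)c1)N1CCCC1` has not yet been measured. It differs from compound 2 in one place: 4-fluorophenyl in place of 2-fluorophenyl on an aromatic carbon.

Among the measured compounds shown here, two measured steps bear on this change. The step of an at least 1.7-fold higher number from compound 1 to compound 2 (0.24 log units; that floor lies within the scatter) and the step of an at least 1.7-fold higher number from compound 1 to compound 3 (0.24 log units; that floor lies within the scatter) both run from a number to a limit. The step that the two limits leave unreadable from compound 2 to compound 3. Changing which fluorophenyl stands on the core therefore left no readable change in this assay among these three compounds. For compound 4 no step beyond the scatter in this assay is therefore expected, and compound 4 is expected to sit at about 50000 nM, with a range from 25000 nM to 100000 nM. The step of a number no higher from compound 2 to compound 4 (the limit leaves the size open) is expected to be none beyond the scatter, most likely ending again at a limit rather than a number.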

Compound 4, half-maximal effective concentration: > 50000 nM
Compound 4 ended at the assay's limit; the forecaster's own chance of this, stated with the estimate: 65%; the middle value lies on the limit itself.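

With 4-fluorophenyl on the shared core, the series now covers 2-fluorophenyl, 3-fluorophenyl and 4-fluorophenyl, and in this assay only compound 1, which carries 3-fluorophenyl, gives a number rather than a limit. That contrast remains weak, as the data show an at least 1.7-fold higher number from compound 1 to compound 4 (0.24 log units; that floor lies within the scatter), so no real difference between these two compounds is established, although the limit leaves room for one. The steps among compound 2, compound 3 and compound 4 cannot be read, as each has a limit at both ends, and moving the fluorine to the place in 4-fluorophenyl adds one more compound to those stopping at the same limit: the limit of > 50000 nM in this assay, at which 3 of the 4 values shown sit.

All four compounds carry a fluorophenyl group at this position, so they say nothing about how a phenyl bearing an amine or a carboxylic acid would behave there. Going by these compounds, the true values of compound 2, compound 3 and compound 4 stay hidden behind the limit, so any difference among them remains unknown.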